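Cinnamamide series: a butyl chain enters the phenyl ring

The source may report more compounds than this note shows. Statements on the series, on what has been measured and on what is new or still open speak of the compounds shown alone.

Measured in a functional assay on CHO cells for inhibition of transient receptor potential cation channel subfamily V member 1 (Homo sapiens); a higher number here means a weaker inhibitor, a lower number a stronger inhibitor:
compound 1 `CC(C)(C)c1ccc(/C=C/C(=O)Nc2ccc3c(c2)NC(=O)CO3)cc1`, 6.5 nM
compound 2 `CC(C)(C)c1ccc(C(=CC(=O)Nc2ccc3c(c2)OCCO3)c2ccc(C(C)(C)C)cc2)cc1`, 2700 nM
compound 3 `O=C(/C=C/c1ccccc1)Nc1ccc2c(c1)OCCO2`, > 4000 nM

Within the data shown here, compound 3 carries an unsubstituted phenyl ring on the cinnamamide and gives only a limit of the assay, > 4000 nM, not a number; it is the one compound of the three that sits at the limit of > 4000 nM in this assay, at which 1 of the 3 values shown sits. Compound 2, with two tert-butyl-bearing aryl rings on the acrylamide, gives 2700 nM. Compound 1, with a single para-tert-butyl aryl ring on a different core, gives 6.5 nM, the lowest of the three values.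

Compound 4 `CCCCc1ccc(/C=C/C(=O)Nc2ccc3c(c2)OCCO3)cc1` is not yet measured. It differs from compound 3 by butyl in place of hydrogen on an aromatic carbon. Among the measured compounds shown here, no measured pair in the set isolates this single change, so its size is not known from the data. Compound 3 sits at the limit of the assay. Given that the para-substituted compound 1 gives 6.5 nM, the expectation for this assay is a clear drop in the number, well beyond the usual scatter, though the core of compound 1 is not that of compound 4 and the tert-butyl group is not a butyl chain. Compound 4 is therefore expected to give about 150 nM, within a range of 20 nM to 1500 nM, an estimated step of an at least 26-fold lower number from compound 3 to compound 4 (1.42 log units; beyond the scatter).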

Compound 4, half-maximal inhibitory concentration: 360 nM
For compound 4 the middle estimate is 2.4-fold (0.38 log units) below the measured one; the measured number falls inside the stated range.
By their numbers in this assay, from the lowest: compound 1; then compound 4; then compound 2. At a limit, above all of these: compound 3.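

In this assay, among these compounds, butyl in place of hydrogen on an aromatic carbon, para to a large group, is the one single change that can be read: it gives an at least 11-fold lower number from compound 3 to compound 4 (1.04 log units; beyond the scatter), and compound 4 lands at 360 nM, a measured number on the shared core. For compound 3 the value is a limit of the assay, > 4000 nM, and not a number. The step therefore stands as a bound and its true size stays unknown because compound 3 sits at that limit: the limit of > 4000 nM in this assay, at which 1 of the 4 values shown sits.

Whether a longer chain, an amine or a carboxylic acid at this same carbon would lower or raise the number is left open by the compounds shown. Compound 1 and compound 4 differ in more than one place, and their values do not separate the contribution of the tert-butyl group from that of the core.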